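Swapping the dichlorobenzyl of compound 1 for methoxybenzyl

The source may report more compounds than this note shows. Statements on the series, on what has been measured and on what is new or still open speak of the compounds shown alone.

Measured compounds:
Compound 1, `Nc1cc(N)c2nc(-c3ccccc3)c(NCc3ccc(Cl)c(Cl)c3)nc2c1`: 4900 nM in a functional assay on NCI-H522 cells (Homo sapiens) for inhibition, read by sulforhodamine B assay, with a stated time of 48 h; a lower number here means a stronger inhibitor of growth, a higher number a weaker inhibitor of growth.
Compound 2, `CCOC(=O)[C@H](CCC(=O)O)NC(=O)c1ccc(Sc2nc3cc(N)cc(N)c3nc2-c2ccccc2)cc1`: < 100000 nM in this assay, a limit of the assay rather than a number.

Within the data shown here, compound 1 holds the only actual number in this assay, so it is the single point of reference here. Compound 2 sits at the limit of < 100000 nM in this assay, at which 1 of the 2 values shown sits, and its value says nothing beyond that. Compound 3, `COc1ccc(CNc2nc3cc(N)cc(N)c3nc2-c2ccccc2)cc1`, differs from compound 1 by 4-methoxyphenyl in place of 3,4-dichlorophenyl on a saturated chain carbon bound to a nitrogen on an aromatic ring. Among the measured compounds shown here, no pair of measured compounds differing in one place exists, so the size of this step has no measured precedent. The expected step of a 1.6-fold higher number from compound 1 to compound 3 (0.21 log units; within the scatter) is a modest loss of potency, near the edge of the usual scatter and with considerable uncertainty. Compound 3 is therefore expected to give 8000 nM, with a range from 2500 nM to 30000 nM.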

Compound 3, concentration for total growth inhibition: 21900 nM
For compound 3 the middle estimate is 2.7-fold (0.44 log units) below the measured one; the measured number falls inside the stated range.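

On a saturated chain carbon bound to a nitrogen on an aromatic ring, 4-methoxyphenyl in place of 3,4-dichlorophenyl gives a 4.5-fold higher number from compound 1 to compound 3 (0.65 log units; beyond the scatter) in this assay as a modest loss of growth inhibition. Among these compounds, this is the first measured step at this place, and it shows that the number responds to the ring substituents even though the leaving and entering groups hold the same count of heavy atoms. Nothing measured here explains the size or direction of this step.

On these data alone, the step changes the chlorines and the methoxy at once, so the share of each in the loss stays open. Also open, as far as these compounds go, is how an unsubstituted phenyl, a single chlorine or a longer chain at this place would read in this assay.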